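Swapping a methyl for fluorine on the benzyl ring

This account rests on a few compounds, and the source may have more. Where it says the series, first, only, none or still open, it means among the compounds named here.

Measured so far:
Compound 1, `O=C(NC(=O)c1ccc(OCc2ccccc2F)cc1)Nc1ccc(Cl)c(-c2nc3ccccc3[nH]2)c1`: 870 nM
Compound 2, `Cc1ccc(COc2ccc(C(=O)NC(=O)Nc3ccc(Cl)c(-c4nc5ccccc5[nH]4)c3)cc2)cc1`: 3190 nM

Both compounds share one core and differ only in the ring attached to the benzylic oxygen. In a functional assay on MNK45 cells (Homo sapiens) for inhibition, read by MTT assay, with a stated time of 48 h (a lower number here means a stronger inhibitor, a higher number a weaker inhibitor), compound 1 gives 870 nM, while compound 2 gives 3190 nM, which is the higher of the two numbers; the step of a 3.7-fold higher number from compound 1 to compound 2 (0.56 log units; beyond the scatter) puts compound 2 beyond the scatter and on the weaker side.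

Compound 3, `O=C(NC(=O)c1ccc(OCc2ccc(F)cc2)cc1)Nc1ccc(Cl)c(-c2nc3ccccc3[nH]2)c1`, is not yet measured. It differs from compound 2 by fluoro in place of methyl on an aromatic carbon, so the benzyl ring keeps its substituent in the same place but carries fluorine instead of methyl.

Going by the values given here, only one measured step is available, a 3.7-fold higher number from compound 1 to compound 2 (0.56 log units; beyond the scatter), and it changes both the kind of substituent and where it sits, so it bears on compound 3 only loosely. It shows that this ring matters in this assay, and it hints that a fluorine-bearing ring can give a lower number than the methyl-bearing one, without telling how much of that came from the position. The expectation for compound 3 is therefore a modest move toward compound 1, a 2.1-fold lower number from compound 2 to compound 3 (0.33 log units; beyond the scatter), and the expected value for compound 3 in this assay is 1500 nM, within 600 nM to 4000 nM.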

Compound 3, half-maximal inhibitory concentration: 350 nM
Beside the measured number, compound 3's estimate is 4.3-fold (0.63 log units) above it, outside the stated range (below it).
By their numbers in this assay, from the lowest: compound 3; then compound 1; then compound 2.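

In this assay, keeping the substituent in one place, para to a large group, and exchanging only methyl for fluoro gives a 9.1-fold lower number from compound 2 to compound 3 (0.96 log units; beyond the scatter); the earlier pair changed kind and place together and could not show that the kind of substituent matters on its own here. Keeping fluorine and changing only its place, with 4-fluorophenyl in place of 2-fluorophenyl, gives a 2.5-fold lower number from compound 1 to compound 3 (0.40 log units; beyond the scatter), so the place of the fluorine counts as well. With both steps beyond the scatter, compound 3 is the strongest inhibitor of these three compounds, which shows that this ring still has room to respond to small changes, though only within this small set.

Nothing here measures why either change lowers the number, so the reason remains unknown. The compounds shown also leave open how a chloro, a methoxy or an amine would read at the same place, and whether a benzyl ring with no substituent at all would fall above or below the fluorine-bearing compounds.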